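A Third Chloro Group on a Benzyl Ether Series

The source may report more compounds than this note shows. Statements on the series, on what has been measured and on what is new or still open speak of the compounds shown alone.

Of the compounds shown here, three sharing one core have been tested. Compound 1 `N[C@]1(C(=O)O)[C@H]2[C@@H](C[C@H]1OCc1ccccc1Cl)[C@]2(F)C(=O)O` gives 4.99 nM in an assay on CHO cells for binding affinity to metabotropic glutamate receptor 2 (Rattus norvegicus); a higher number here means a weaker inhibitor, a lower number a stronger inhibitor. Compound 2 `N[C@]1(C(=O)O)[C@H]2[C@@H](C[C@H]1OCc1cc(Cl)cc(Cl)c1)[C@]2(F)C(=O)O` gives 5.61 nM, and compound 3 `N[C@]1(C(=O)O)[C@H]2[C@@H](C[C@H]1OCc1ccc(Cl)cc1Cl)[C@]2(F)C(=O)O` gives 3.89 nM. The cores of compound 1 and compound 2 differ by 3,5-dichlorophenyl in place of 2-chlorophenyl on a saturated chain carbon bound to an oxygen on a saturated carbon, which gives a 1.1-fold higher number from compound 1 to compound 2 (0.05 log units; within the scatter). Compound 1 and compound 3 differ by chloro in place of hydrogen on an aromatic carbon, with a 1.3-fold lower number from compound 1 to compound 3 (0.11 log units; within the scatter). Between compound 2 and compound 3 the step is a 1.4-fold lower number from compound 2 to compound 3 (0.16 log units; within the scatter).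

Compound 4 `N[C@]1(C(=O)O)[C@H]2[C@@H](C[C@H]1OCc1cc(Cl)c(Cl)c(Cl)c1)[C@]2(F)C(=O)O` has not yet been measured. It differs from compound 2 by chloro in place of hydrogen on an aromatic carbon. This is the same kind of change as from compound 1 to compound 3, but not the same: there the entering chloro sat meta to a chloro group and para to a large group, whereas here it sits ortho to two chloro groups and para to a large group.

Because compound 2 gives 5.61 nM and the earlier step was a 1.3-fold lower number from compound 1 to compound 3 (0.11 log units; within the scatter), the expected step is a 1.2-fold lower number from compound 2 to compound 4 (0.10 log units; within the scatter). Compound 4 is therefore estimated at 4.5 nM, between 2.5 nM and 9 nM.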

Compound 4, inhibition constant: 3.67 nM
For compound 4 the middle estimate is 1.2-fold (0.09 log units) above the measured one; the range from low to high includes it.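

Adding the chloro group gives a 1.5-fold lower number from compound 2 to compound 4 (0.18 log units; within the scatter) in this assay, with the new chloro group ortho to two chloro groups and para to a large group. Carried from one core to the other, the change gives steps that agree as far as they can be read: the same change on two cores in this assay, a 1.3-fold lower number (0.11 log units; within the scatter) from compound 1 to compound 3 and a 1.5-fold lower number (0.18 log units; within the scatter) from compound 2 to compound 4, 1.2-fold (0.08 log units) apart, within the scatter of two such steps. This shows that in these two pairs the replacement of hydrogen by chloro gives no step beyond the scatter, but it does not show that the change truly improves binding, and two pairs with the chloro group in different places do not establish a rule for the whole series.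

All four compounds carry only chloro groups on the aromatic ring. As far as these compounds go, it remains open whether a methoxy group, a nitrile or a trifluoromethyl group in the same place would give a step beyond the scatter, and whether the chloro step would hold on a core with an unsubstituted phenyl group.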